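The source may report more compounds than this note shows. Statements on the series, on what has been measured and on what is new or still open speak of the compounds shown alone.

Measured so far in a functional assay on MCF7 cells (Homo sapiens) for inhibition; a lower number here means a stronger inhibitor, a higher number a weaker inhibitor:
compound 1 `CC/C(=C(/c1ccc(/C=C/C(=O)O)cc1)c1cc2ccccc2[nH]1)c1ccc(Cl)cc1`, 343 nM
compound 2 `CC/C(=C(/c1ccc(/C=C/C(=O)O)cc1)c1cc2ccccc2[nH]1)c1cccc(F)c1C#N`, 40 nM
compound 3 `CC/C(=C(/c1ccc(/C=C/C(=O)O)cc1)c1cc2ccccc2[nH]1)c1ccc(C#N)cc1Cl`, 49 nM

Compound 1 carries the highest number of the three in this assay; compound 2 and compound 3 lie close together, and their difference a 1.2-fold higher number from compound 2 to compound 3 (0.09 log units; within the scatter) stays inside the scatter. Both depart from compound 1 by replacing the 4-chlorophenyl on the double-bonded chain carbon with a cyano-bearing ring, and both moves lower the number by a clear margin: an 8.6-fold lower number from compound 1 to compound 2 (0.93 log units; beyond the scatter) and a 7.0-fold lower number from compound 1 to compound 3 (0.85 log units; beyond the scatter).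

Compound 4 `CC/C(=C(/c1ccc(/C=C/C(=O)O)cc1)c1cc2ccccc2[nH]1)c1ccc(Cl)cc1C#N` keeps the 4-chlorophenyl of compound 1 and adds a single group: cyano in place of hydrogen on an aromatic carbon. Read one bond further out, this is 4-chlorophenyl becoming 4-chloro-2-cyanophenyl. Among the compounds with values here, no measured step isolates a cyano entering on an otherwise unchanged ring, so the two steps from compound 1 serve only as a guide; each of them also shifted the chloro or brought a fluoro in. Still, both carry a cyano and both ended near the same number. The expectation for compound 4 in this assay is therefore a drop, somewhat smaller than those two moves given that less changes: a 4.6-fold lower number from compound 1 to compound 4 (0.66 log units; beyond the scatter). Compound 4 is estimated at 75 nM, with a range from 30 nM to 190 nM.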

Compound 4, half-maximal inhibitory concentration: 14 nM
The estimate for compound 4 lay 5.4-fold (0.73 log units) above the measured number; the whole stated range lies above it.
By their numbers in this assay, from the lowest: compound 4; then compounds 2 and 3 (each within the scatter of the next); then compound 1.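

Cyano in place of hydrogen on an aromatic carbon, ortho to a large group and meta to a chloro group, is now seen on an otherwise unchanged ring in this assay, and this single change gives a 25-fold lower number from compound 1 to compound 4 (1.39 log units; beyond the scatter), the only step of this series printed as large. Where the cyano sits on the ring also matters, or the groups that accompany it do: 4-chloro-2-cyanophenyl outdoes both earlier cyano-bearing rings, with a 3.5-fold lower number from compound 3 to compound 4 (0.54 log units; beyond the scatter) and a 2.9-fold lower number from compound 2 to compound 4 (0.46 log units; beyond the scatter), so compound 4 holds the lowest number of the four, while the earlier compounds 2 and 3 could not be told apart. No measurement at hand explains why this ring arrangement gives the lowest number.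

Open, from the compounds shown here alone, is whether a methoxy or a primary amide on this same aromatic carbon would lower the number as cyano does, and whether cyano would do so on a ring without the chloro group. The effect of adding cyano also rests on this one pair, so whether it holds with a different group on the rest of the shared core remains unsettled.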